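Aryl swap on the saturated ring of compound 1

This account rests on a few compounds, and the source may have more. Where it says the series, first, only, none or still open, it means among the compounds named here.

Two compounds share the core and have numbers in an assay on isolated protein for inhibition of Rho-associated protein kinase 2 (Homo sapiens), read by a luciferase reporter; on this read-out higher numbers stand for weaker inhibition and lower numbers for stronger inhibition. Compound 1 `O=C(Nc1cc2cc[nH]c(=O)c2cc1Cl)C1CNCC1c1ccc(F)cc1` gives 9 nM and stands lowest of the two, hence strongest on this read-out. Going by the values given here, compound 2 `O=C(Nc1cc2cc[nH]c(=O)c2cc1Cl)C1(c2ccccc2)CCNC1` gives 240 nM, a gap that lies well beyond the scatter; no single-point step between the two is defined, so their values are simply set side by side.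

Compound 3 `CCc1cccc(C2CNCC2C(=O)Nc2cc3cc[nH]c(=O)c3cc2Cl)c1` has not been measured. It differs from compound 1 in one place: 3-ethylphenyl in place of 4-fluorophenyl on a saturated ring carbon. Among the compounds with values here, the 4-fluorophenyl of compound 1 is the only aryl group on that saturated ring carbon for which a value exists, so the effect of 3-ethylphenyl rests on no measured step. A modest weakening is expected, a 2.8-fold higher number from compound 1 to compound 3 (0.44 log units; beyond the scatter), likely near the edge of the scatter rather than far beyond it. Compound 3 is therefore estimated at 25 nM, with a range from 8 nM to 80 nM.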

Compound 3, half-maximal inhibitory concentration: 4 nM
Estimate against measurement, compound 3: 6.3-fold (0.80 log units) above; measured number outside the range, below it.
By their numbers in this assay, from the lowest: compound 3; then compound 1; then compound 2.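

In this assay the saturated ring carbon two ring bonds from the ring nitrogen takes 3-ethylphenyl in place of 4-fluorophenyl with a gain, not a loss (a 2.3-fold lower number from compound 1 to compound 3 (0.35 log units; beyond the scatter)). The 4-fluorophenyl is therefore not required at this position: an aryl group of carbon only, with no fluorine, serves at least as well, and the series stays at low numbers on this read-out with a different substituent on the phenyl. Nothing at hand accounts for the direction or size of this modest step.

The step changes the substituent and its place on the phenyl together, and the compounds shown do not separate these two changes. As far as these compounds go, how far this position tolerates further change also stays open, for example a methoxy group, a longer chain or an amine on that phenyl.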